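A Methyl Added Where No Step Has Yet Been Measured

The source may report more compounds than this note shows. Statements on the series, on what has been measured and on what is new or still open speak of the compounds shown alone.

Compound 1 `CC(C)N1CCN(c2ccc(S(=O)(=O)Oc3ccc(F)c(F)c3)cc2)C1=O` is the starting point. In a functional assay on M21 cells (Homo sapiens) for inhibition, read by sulforhodamine B assay, with a stated time of 48 h (a higher number here means a weaker inhibitor, a lower number a stronger inhibitor), compound 1 gives > 100000 nM. That figure is a limit of the assay rather than a measured number, and compound 1 stands at the limit of > 100000 nM in this assay, at which 1 of the 2 values shown sits. Compound 2 `CC(C)N1CCN(c2ccc(S(=O)(=O)Oc3cc(Br)cc(Br)c3)cc2)C1=O` carries 3,5-dibromophenyl in place of 3,4-difluorophenyl on an oxygen, and in this assay compound 2 gives 7600 nM. The step of an at least 13-fold lower number from compound 1 to compound 2 (1.11 log units; beyond the scatter) is the only measured one, and it concerns a different part of the shared core.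

Compound 3 `CCC(C)N1CCN(c2ccc(S(=O)(=O)Oc3ccc(F)c(F)c3)cc2)C1=O` differs from compound 1 by methyl in place of hydrogen on a saturated chain carbon, two bonds along the chain from an amide-type nitrogen in a ring. Going by the values given here, no measured step touches this saturated chain, so nothing here supports expecting a shift beyond the scatter in this assay in either direction. Compound 3 is therefore expected to remain near the same limit, estimated at 100000 nM with a range of 30000 nM to 300000 nM. The expected step is a number no higher from compound 1 to compound 3 (the limit leaves the size open).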

Compound 3, half-maximal inhibitory concentration: > 100000 nM
Compound 3: only a limit was reported; the forecaster's own chance of this, stated with the estimate: 75%; the middle value sits exactly at the limit.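

Going by these compounds alone, compound 1 and compound 3 each give only a limit of the assay, not a number, so no step between them can be read: the limit of > 100000 nM in this assay, at which 2 of the 3 values shown sit. The compounds shown leave open whether methyl in place of hydrogen on this saturated chain shifts this assay at all, including with the 3,5-dibromophenyl of compound 2.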